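The source may hold more compounds than are shown below. What is called first, only, known or untested is meant among the compounds shown, and "the series" means these compounds.

Compound 2 `CCCCCCCCCCOCCc1scnc1C` is the shorter-chain member of the pair measured so far. In a functional assay on MG-22A cells (Mus musculus) for cytotoxicity, read by crystal violet staining (a higher number here means that more compound is tolerated, a lower number that less compound is tolerated), compound 2 gives 38800 nM, the lower of the two numbers recorded; the nearest is compound 1 `CCCCCCCCCCCOCCc1scnc1C`, which in this assay gives 47100 nM. Within the data shown here, the only step recorded, a 1.2-fold lower number from compound 1 to compound 2 (0.08 log units; within the scatter), is a change of one chain carbon and lies within the scatter.

Compound 3 `CCCCCCCOCCc1scnc1C` is the next member to be measured. Compared with compound 2 it carries hydrogen in place of propyl on a saturated chain carbon, seven bonds along the chain from an oxygen on a saturated carbon. This is a larger cut of the same chain than the step from compound 1 to compound 2, and that step bears on it, though only as a one-carbon change. Among the measured compounds shown here, with a single step within the scatter as the only guide, a shift beyond the scatter is not established in either direction; if anything, a somewhat higher number is expected. For compound 3 the estimated step in this assay is a 1.3-fold higher number from compound 2 to compound 3 (0.11 log units; within the scatter). Compound 3 is therefore expected at 50000 nM, with a range from 20000 nM to 130000 nM.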

Compound 3, concentration lethal to 50% of the cells: 37300 nM
Estimate against measurement, compound 3: 1.3-fold (0.13 log units) above; low and high end bracket the measured number.
By their numbers in this assay, from the lowest: compounds 3, 2 and 1 (each within the scatter of the next).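

In this assay, the larger cut at this place, hydrogen in place of propyl seven bonds along the chain from an oxygen on a saturated carbon, stays within the scatter (a 1.0-fold lower number from compound 2 to compound 3 (0.02 log units; within the scatter)). Hydrogen in place of butyl at the same place also stays within the scatter (a 1.3-fold lower number from compound 1 to compound 3 (0.10 log units; within the scatter)), so across these three compounds the number does not follow chain length, as the single one-carbon step could not show. Nothing measured bears on why the number holds across these chains.

Going by these compounds, whether a much shorter chain or a chain longer than that of compound 1 would give a step beyond the scatter remains open. Also open, on these data alone, is how an amine or a carboxylic acid in place of the chain would read in this assay.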